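This account rests on a few compounds, and the source may have more. Where it says the series, first, only, none or still open, it means among the compounds named here.

Working notes on the series. Of the compounds shown here, two have numbers so far, compound 1 (`COc1ccc(/C=N/NC(=O)Nc2ccc(Oc3ccnc4[nH]ccc34)c(F)c2)cc1`) and compound 2 (`O=C(N/N=C/c1ccc([N+](=O)[O-])cc1)Nc1ccc(Oc2ccnc3[nH]ccc23)cc1`). In a functional assay on HepG2 cells (Homo sapiens) for antiproliferative activity, read by MTT assay, with a stated time of 72 h (a higher number here means a weaker inhibitor, a lower number a stronger inhibitor), compound 1 gives 1770 nM and compound 2 gives 4620 nM as the higher of the two numbers, a gap beyond the scatter. Compound 3 (`COc1ccc(/C=N/NC(=O)Nc2ccc(Oc3ccnc4[nH]ccc34)cc2)cc1`) has not yet been measured. It departs from compound 2 in one place (methoxy in place of nitro on an aromatic carbon), with methoxy in place of nitro on an aromatic carbon, para to a large group, so that 4-nitrophenyl becomes 4-methoxyphenyl. Within the data shown here, no step between measured compounds isolates this change, and the evidence for any forecast is thin. A lower number is expected for compound 3 since compound 1 with 4-methoxyphenyl on a different core gives 1770 nM in the same read-out. In this assay the estimated step of a 1.9-fold lower number from compound 2 to compound 3 (0.28 log units; within the scatter) is modest and is not expected to lie clearly beyond the scatter. For compound 3 the estimated value is 2400 nM within an expected range from 900 nM to 6000 nM at the upper end.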

Compound 3, half-maximal inhibitory concentration: 9740 nM
The estimate for compound 3 lay 4.1-fold (0.61 log units) below the measured number; measured number outside the range, above it.
By their numbers in this assay, from the lowest: compound 1; then compound 2; then compound 3.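

At the aromatic carbon para to a large group, this assay now gives a direct reading: methoxy in place of nitro produces a 2.1-fold higher number from compound 2 to compound 3 (0.32 log units; beyond the scatter) on an otherwise unchanged structure, so in this pair 4-nitrophenyl carries the lower number. A second place is also isolated, since hydrogen in place of fluoro on an aromatic carbon, with 4-methoxyphenyl held constant, produces a 5.5-fold higher number from compound 1 to compound 3 (0.74 log units; beyond the scatter) and leaves compound 3 with the highest number of the three; the lower number of compound 1 therefore goes with the fluoro and not with 4-methoxyphenyl alone. Nothing measured here speaks to the reason for either step.

The compounds shown leave open whether the fluoro step carries over when 4-nitrophenyl replaces 4-methoxyphenyl, and so whether the two changes act independently or depend on each other. They also leave open how the para place responds to other groups, such as an amine, a carboxylic acid or a plain hydrogen, since only nitro and methoxy have been read there so far.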